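The source may report more compounds than this note shows. Statements on the series, on what has been measured and on what is new or still open speak of the compounds shown alone.

Measured compounds:
compound 1, `O=C(Nc1cc(-c2ccccc2)nn1-c1ccccc1)c1ccc(F)c(F)c1`: 20 nM
compound 2, `O=C(Nc1cc(-c2ccccc2)nn1-c1ccccc1)c1cnccn1`: 400 nM

Both compounds carry the same core and differ only in the group on the carbonyl carbon. In an assay on isolated protein with metabotropic glutamate receptor 5 (Rattus norvegicus) as the target (on this read-out higher numbers stand for an effect only at larger amounts of compound and lower numbers for an effect already at smaller amounts), compound 1 gives 20 nM, whereas compound 2 gives 400 nM. For the measured compounds named here, of the two numbers, compound 2 stands at the higher one; the only step measured so far, a 20-fold higher number from compound 1 to compound 2 (1.30 log units; beyond the scatter), runs from the 3,4-difluorophenyl compound to the pyrazin-2-yl compound and is large.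

Compound 3, `O=C(Nc1cc(-c2ccccc2)nn1-c1ccccc1)c1ccccc1F`, is not yet measured. Its change from compound 2 is 2-fluorophenyl in place of pyrazin-2-yl on a carbonyl carbon. Going by the values given here, this change largely retraces the single measured step, since a fluorinated phenyl ring again replaces the pyrazine, so a step of similar size in the opposite direction is expected in this assay, namely a 13-fold lower number from compound 2 to compound 3 (1.12 log units; beyond the scatter). Compound 3 is therefore estimated at 30 nM, with a range from 10 nM to 100 nM.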

Compound 3, half-maximal effective concentration: 100 nM
Estimate against measurement, compound 3: 3.3-fold (0.52 log units) below; measured number inside the range.
By their numbers in this assay, from the lowest: compound 1; then compound 3; then compound 2.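

In this assay, 2-fluorophenyl in place of pyrazin-2-yl on the carbonyl carbon gives a 4.0-fold lower number from compound 2 to compound 3 (0.60 log units; beyond the scatter) and so recovers only part of the gap opened by the pyrazine. The two fluorinated phenyl groups are not interchangeable either: the change to 2-fluorophenyl gives a 5.0-fold higher number from compound 1 to compound 3 (0.70 log units; beyond the scatter) and shows that, among the compounds shown, the number at this position depends on which fluorinated phenyl group is present and not simply on a carbon-only ring. No evidence is at hand on why the three groups rank in this order.

The compounds shown leave open what a plain phenyl ring without fluorine would give at this position, and so how much of the difference belongs to fluorine at all. They also leave open whether a pyridin-2-yl ring would fall nearer the pyrazin-2-yl compound or the fluorinated phenyl compounds.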